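Removing the ring nitrogen's amino group in a weak inhibitor series

A few compounds are considered here, and "the series" means these few. Any claim that something is new, unique, unknown or untested is made for them only; others in the source may bear on it.

Measured compounds:
compound 1 `NN1C(=O)/C(=C/c2ccc(Cl)cc2)SC1=S`: "not active" (no number reported)
compound 2 `CC(=O)/N=C1\NC(=O)/C(=C/c2ccc(-c3ccc([N+](=O)[O-])cc3)o2)S1`: 78000 nM
compound 3 `COc1ccc(/C=C2\SC(=S)N(N)C2=O)cc1`: 155000 nM

In an assay for inhibition of LL-diaminopimelate aminotransferase, chloroplastic (Arabidopsis thaliana) (a higher number here means a weaker inhibitor, a lower number a stronger inhibitor), compound 1 gives "not active" (no number reported), so no single number places it on the scale. Compound 2 gives 78000 nM and compound 3 gives 155000 nM; both are weak, and the two values lie close together. Compound 4 `O=C1NC(=S)S/C1=C\c1ccc(Cl)cc1` differs from compound 1 by hydrogen in place of amino on an amide-type nitrogen in a ring. Within the data shown here, no step between measured compounds describes this change, so the size of its effect in this assay cannot be read from the data. Since compound 1 is reported as not active, the step may end anywhere from a similarly silent result to the weak range shown by compound 3. Compound 4 is therefore estimated at 120000 nM, within a range from 30000 nM to 500000 nM, and a further report of no activity is also expected to be possible.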

Compound 4, half-maximal inhibitory concentration: > 200000 nM
Compound 4: only a limit was reported; the forecaster's own chance of this, stated with the estimate: 50%; at least 1.6-fold (0.22 log units) between middle value and limit.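

Compound 4 gives > 200000 nM, which is a limit and not a number. Among these compounds, compound 1 gives "not active" (no number reported), so no step between compound 1 and compound 4 can be read. The compounds shown leave open whether hydrogen in place of amino on the amide-type nitrogen changes inhibition at all.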